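Lengthening a Small Chain: Maximal Response Expected to Hold

This account rests on a few compounds, and the source may have more. Where it says the series, first, only, none or still open, it means among the compounds named here.

Of the compounds shown here, three built around a shared scaffold have been measured. Compound 1 `CCn1ncnc1-c1ccccc1NCC1=NCCN1` reaches 107% in a functional assay with Alpha-1A adrenergic receptor (Homo sapiens) as the target, read by calcium flux; a higher number here means a larger maximal response, a lower number a smaller maximal response. Compound 2 `CC(C)n1ncnc1-c1ccccc1NCC1=NCCN1` differs from compound 1 only by methyl in place of hydrogen on a saturated chain carbon bound to an aromatic nitrogen and a saturated chain carbon, and in this assay compound 2 reaches 104%. The change from compound 1 to compound 2 gave a number 3 percentage points lower from compound 1 to compound 2 (within the scatter), so the two compounds behave alike within the usual scatter.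

Compound 3 `Cn1cccc1-c1ccccc1NCC1=NCCN1` carries a different core; the difference between the core of compound 1 and the core of compound 3 is not broken down here. In this assay compound 3 reaches 103%, a number that lies within the scatter of both compound 1 and compound 2.

Compound 4 `CCn1cccc1-c1ccccc1NCC1=NCCN1` has not yet been measured. It differs from compound 3 by methyl in place of hydrogen on a saturated chain carbon bound to an aromatic nitrogen. For the measured compounds named here, this is the same kind of change as the one from compound 1 to compound 2, though the surroundings are not identical: in compound 1 the carbon that gains the methyl is bound to an aromatic nitrogen and a saturated chain carbon, whereas in compound 3 it is bound to an aromatic nitrogen. Because the earlier step gave a number 3 percentage points lower from compound 1 to compound 2 (within the scatter), the step from compound 3 to compound 4 in this assay is expected to be small, around a number 1 percentage points higher from compound 3 to compound 4 (within the scatter). Compound 4 is therefore estimated to reach 104%, most likely between 92% and 116%.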

Compound 4, largest response reached (reported as maximal response), in percent of the reference or control that the assay uses: 93%
For compound 4 the middle estimate is 11 percentage points above the measured one, within the range that was stated.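

Measured, the methyl in place of hydrogen on a saturated chain carbon bound to an aromatic nitrogen gives a number 10 percentage points lower from compound 3 to compound 4 (within the scatter) in this assay, so on this core, too, the change does not move the maximal response beyond the usual scatter. Set beside the earlier step, the two cores give no sign that the change behaves differently from one to the other: the same change on two cores in this assay, a number 3 percentage points lower (within the scatter) from compound 1 to compound 2 and a number 10 percentage points lower (within the scatter) from compound 3 to compound 4, 7 percentage points apart, within the scatter of two such steps. This shows only that, on these two cores, the change leaves the maximal response within the scatter; it does not show that the two steps are truly equal, that the methyl has any real effect on the response, or that the same would hold on a third core.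

The compounds shown leave open how far this tolerance extends, since they do not tell what a longer chain such as butyl, or a chain ending in an amine or a carboxylic acid, would do at this place on either core. They also say nothing about how strongly the compounds act at the receptor at a given concentration, since the only read-out here is the largest response reached.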